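This account rests on a few compounds, and the source may have more. Where it says the series, first, only, none or still open, it means among the compounds named here.

In a functional assay on the whole organism with Mus musculus as the target, in the maximal electroshock model (on this read-out lower numbers stand for an effect already at smaller amounts and higher numbers for an effect only at larger amounts of compound), compound 1 `OC1CCN(c2ccc(-c3ccccc3)nn2)CC1` gives 86 mg/kg and compound 2 `O=[N+]([O-])c1cccc(-c2ccc(N3CCC(O)CC3)nn2)c1` gives 79 mg/kg, so compound 2 stands level with compound 1, within the scatter. Compound 3 `Cc1cccc(-c2ccc(N3CCC(O)CC3)nn2)c1` has methyl in place of nitro on an aromatic carbon, meta to a large group: methyl in place of nitro on an aromatic carbon. Among the measured compounds shown here, the only measured step bearing on this position is a 1.1-fold lower number from compound 1 to compound 2 (0.04 log units; within the scatter), which introduces the nitro and stays within the scatter. No step beyond the scatter is therefore expected in this assay. The expected step is a 1.0-fold higher number from compound 2 to compound 3 (0.01 log units; within the scatter). For compound 3 the estimated value is 80 mg/kg, with an expected range of 40 mg/kg to 160 mg/kg.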

Compound 3, dose for half-maximal effect: 36 mg/kg
Compound 3: middle estimate off by 2.2-fold (0.35 log units), on the high side; the measured number lies below the stated range.
By their numbers in this assay, from the lowest: compound 3; then compounds 2 and 1 (each within the scatter of the next).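

The aromatic carbon meta to a large group is not indifferent in this assay: methyl in place of nitro gives a 2.2-fold lower number from compound 2 to compound 3 (0.34 log units; beyond the scatter) while nitro in place of hydrogen had stayed within the scatter. Methyl in place of hydrogen gives a 2.4-fold lower number from compound 1 to compound 3 (0.38 log units; beyond the scatter) as well, so among these three compounds only methyl moves the number beyond the scatter. Nothing at hand explains this difference between methyl and nitro.

Open, as far as these compounds go, is whether ethyl, methoxy or chlorine at this carbon would match methyl. Also open, from the compounds shown here alone, is whether methyl on another carbon of this ring gives a similar step.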